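The source may hold more compounds than are shown below. What is called first, only, known or untested is meant among the compounds shown, and "the series" means these compounds.

The study concerns three compounds built on a shared core. Compound 1 `Cn1cccc1-c1ccccc1NCC1=NCCN1` and compound 2 `CCn1nccc1-c1ccccc1NCC1=NCCN1` have been measured, while compound 3 `Cn1nccc1-c1ccccc1NCC1=NCCN1` has not. In a functional assay with Alpha-1B adrenergic receptor (Homo sapiens) as the target, read by calcium flux (a lower number here means a smaller maximal response, a higher number a larger maximal response), compound 1 gives 0%. In this assay compound 2 gives 0%, level with compound 1 at the digits shown, so the two stand together within the scatter of the measurement. Compound 2 therefore sits at the floor of what has been measured, with a maximal response that cannot be told apart from none, and compound 1 shares that position.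

The change from compound 2 to compound 3 is hydrogen in place of methyl on a saturated chain carbon bound to an aromatic nitrogen. For the measured compounds named here, no step between measured compounds isolates this change, so any expectation for compound 3 rests on the two existing values. Compound 1 with 0% and compound 2 with 0% differ in more than one place and yet agree, which gives no hint of movement. For compound 3 the expected step is no change at the digits printed from compound 2 to compound 3 (within the scatter), none beyond the scatter. Compound 3 is estimated at 0% in this assay, within a range from 0% to 10%.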

Compound 3, largest response reached (reported as maximal response), in percent of the reference or control that the assay uses: 0%
Compound 3: the middle estimate sits on the measured number at the digits printed; measured number inside the range.
By their numbers in this assay, from the lowest: compounds 1, 2 and 3 (each within the scatter of the next).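

Hydrogen in place of methyl on a saturated chain carbon bound to an aromatic nitrogen, which is ethyl to methyl, gives in this assay no change at the digits printed from compound 2 to compound 3 (within the scatter), so this single change can now be read alone, where the earlier pair differed in more than one place. The second new step, 1-methyl-1H-pyrazol-5-yl in place of 1-methyl-1H-pyrrol-2-yl on an aromatic carbon, gives no change at the digits printed from compound 1 to compound 3 (within the scatter), so neither of the two separate changes moves the maximal response in this assay away from the floor on which all three compounds stand. Nothing is available that would explain this agreement.

Since every reading sits at that floor, these steps cannot show whether either change would matter in a compound with a measurable response. The compounds shown leave open whether a longer chain such as propyl on the aromatic nitrogen, or an amine at the end of that chain, would lift the response in this assay above the level of these three.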